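The source may report more compounds than this note shows. Statements on the series, on what has been measured and on what is new or still open speak of the compounds shown alone.

Measured so far in a toxicity assay on CHO cells (Cricetulus griseus) for cytotoxicity, read by MTT assay, with a stated time of 72 h; on this read-out lower numbers stand for stronger inhibition and higher numbers for weaker inhibition:
- compound 1 `O=C1/C(=C/c2ccc(O)cc2)S/C(=N\c2ccccc2)N1Cc1ccco1` gives > 250000 nM as a limit of the assay, not a number
- compound 2 `O=C1/C(=C/c2ccccn2)S/C(=N\c2ccccc2)N1Cc1ccco1` gives > 250000 nM as a limit of the assay, not a number
- compound 3 `Cc1ccc(/C=C2\S/C(=N\c3ccccc3)N(Cc3ccco3)C2=O)cc1` gives 185000 nM as a measured number

Compound 3 is the only one of these with a number. The other two sit at the limit of > 250000 nM in this assay, at which 2 of the 3 values shown sit, and that is a limit only.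

Next is compound 4 `COc1ccc(/C=C2\S/C(=N\c3ccccc3)N(Cc3ccco3)C2=O)cc1` with methoxy in place of methyl on an aromatic carbon, para to a large group. The counted difference is methoxy in place of methyl on an aromatic carbon in full.

Going by the values given here, two measured steps bear on this. On the same aromatic carbon, methyl in place of hydroxy gives an at least 1.3-fold lower number from compound 1 to compound 3 (0.13 log units; that floor lies within the scatter) and this is the closest comparison. With 4-methylphenyl in place of pyridin-2-yl, the wider comparison is an at least 1.3-fold lower number from compound 2 to compound 3 (0.13 log units; that floor lies within the scatter) and it shows the same floor. Among the compounds with values here, both are floors only, and no methoxy compound has been measured. No step beyond the scatter is therefore expected in this assay in either direction. The estimated step is a 1.0-fold higher number from compound 3 to compound 4 (0.01 log units; within the scatter) and no more. Compound 4 is expected at 190000 nM with an estimated range of 100000 nM to 300000 nM overall.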

Compound 4, half-maximal inhibitory concentration: > 250000 nM
Compound 4 ended at the assay's limit (the forecaster's own chance of this, stated with the estimate: 35%); middle value at least 1.3-fold (0.11 log units) away from the limit.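

Methoxy in place of methyl on this aromatic carbon gives, in this assay, an at least 1.3-fold higher number from compound 3 to compound 4 (0.13 log units; that floor lies within the scatter), the first step read at this position with no free hydroxy or ring nitrogen involved. Compound 4 gives > 250000 nM, which is a limit and not a number. The steps to compound 4 from compound 1 and from compound 2 cannot be read, compound 3 stays the only compound with a number, and the set now rests mostly on one ceiling: the limit of > 250000 nM in this assay, at which 3 of the 4 values shown sit.

On these data alone, what an amine, a carboxylic acid or a longer chain on this aromatic carbon would give stays open. As far as these compounds go, whether methyl and methoxy differ at all here also stays open, the one readable floor lying within the scatter.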